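This account rests on a few compounds, and the source may have more. Where it says the series, first, only, none or still open, it means among the compounds named here.

Measured so far:
- compound 1, `Cc1cnc(Nc2ccc(C#N)cc2)nc1Nc1c(F)cc(-c2ccsc2)cc1F`: 261000 nM
- compound 2, `Cc1cc(-c2ccnc3ccccc23)cc(C)c1Nc1ccnc(Nc2ccc(C#N)cc2)n1`: 3500 nM

Both were tested in a toxicity assay on MT4 cells (Homo sapiens) for cytotoxicity, read by MTT assay, with a stated time of 5 days; a lower number here means that less compound is tolerated, a higher number that more compound is tolerated. Of the two numbers, compound 2 stands lowest, so less of it is tolerated by the cells than of compound 1, and the gap between the two values is well beyond the usual scatter. For the measured compounds named here, no single-change step between these two compounds is available, since they differ in more than one place.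

The next compound, compound 3, `COc1ncc(-c2cc(C)c(Nc3ccnc(Nc4ccc(C#N)cc4)n3)c(C)c2)cn1`, is not yet measured in this assay. It differs from compound 2 in one place: 2-methoxypyrimidin-5-yl in place of quinolin-4-yl on an aromatic carbon.

Going by the values given here, with no comparable step among the measured compounds, the direction of the change can only be guessed. A modest rise in tolerated concentration is expected, a 2.6-fold higher number from compound 2 to compound 3 (0.41 log units; beyond the scatter), though a change within the scatter is just as plausible. For compound 3 the estimate in this assay is 9000 nM, within a range from 2500 nM to 35000 nM.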

Compound 3, half-maximal cytotoxic concentration: 4800 nM
Estimate against measurement, compound 3: 1.9-fold (0.27 log units) above; low and high end bracket the measured number.
By their numbers in this assay, from the lowest: compounds 2 and 3 (each within the scatter of the next); then compound 1.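

In this assay the step from quinolin-4-yl to 2-methoxypyrimidin-5-yl is a 1.4-fold higher number from compound 2 to compound 3 (0.14 log units; within the scatter) and so cannot be told apart from repeat-measurement noise. At this aromatic carbon, meta to two methyl groups, the cells therefore do not distinguish a two-ring group from a smaller single-ring group with more nitrogen and oxygen atoms and more hydrogen-bond acceptors. Nothing available explains why these two groups read alike.

Both groups shown at this position are aromatic rings, so it remains open whether the number would stay level with an amine, a carboxylic acid or a longer carbon chain there. From the compounds shown here alone, it is also open whether a group at this position could move the number beyond the scatter at all.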